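Compound 4: methylcarbamoyl in place of methyl

The source may hold more compounds than are shown below. What is called first, only, known or untested is meant among the compounds shown, and "the series" means these compounds.

Going by the values given here, in a physicochemical assay for solubility, read by LC-MS, in phosphate buffer, with a stated time of 24 h, at pH 7.4 (a higher number here means a more soluble compound, a lower number a less soluble compound), compound 3 (`Cc1cc(-c2cnc(NCc3c(F)ccc4c3CCO4)c3cn[nH]c(=O)c23)n(C)n1`) gives 1000 nM, the only true number in the set. Compound 1 (`CC(=O)N1CCC(c2cnc(NCc3c(F)ccc4c3CCO4)c3cn[nH]c(=O)c23)CC1`) gives < 2000 nM, which is a limit and not a number. Compound 2 (`Cc1nc(CN(C)C)ccc1-c1cnc(NCc2c(F)ccc3c2CCO3)c2cn[nH]c(=O)c12`) gives > 1000000 nM, which is also a limit. Going by these compounds, the comparison with the first of these stays open, as a step that the limit leaves unreadable from compound 1 to compound 3 shows, while an at least 1000-fold lower number from compound 2 to compound 3 (3.00 log units; beyond the scatter) puts compound 3 far down from the other limit.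

Compound 4 (`CNC(=O)c1cc(-c2cnc(NCc3c(F)ccc4c3CCO4)c3cn[nH]c(=O)c23)n(C)n1`) has methylcarbamoyl in place of methyl on an aromatic carbon.

Among the compounds with values here, no measured step touches this methyl. The nearest evidence is an at least 500-fold higher number from compound 1 to compound 2 (2.69 log units; beyond the scatter) together with the two steps above. Each of these exchanges the whole group on the core, and the two readable ones are large. They show that the read-out can move widely across this small set, but they are a loose guide to a change confined to one small group. A modest upward step is therefore expected, near the edge of the scatter, with wide uncertainty. The estimate for this change is a 2.5-fold higher number from compound 3 to compound 4 (0.40 log units; beyond the scatter), an expected rather than measured step. Compound 4 is expected at 2500 nM, with an estimated range of 500 nM to 12000 nM.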

Compound 4, solubility: 7000 nM
Beside the measured number, compound 4's estimate is 2.8-fold (0.45 log units) below it; the range from low to high includes it.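

In this assay, going by these compounds alone, a 7.0-fold higher number from compound 3 to compound 4 (0.85 log units; beyond the scatter) is the first step in the set confined to one small group, methylcarbamoyl in place of methyl on an aromatic carbon of the five-membered aromatic ring, and it lies beyond the scatter; the earlier steps all exchanged the whole group on the core. The set now also holds an at least 3.5-fold higher number from compound 1 to compound 4 (0.54 log units; beyond the scatter), a readable comparison with compound 1 that compound 3 could not give, though it is only a bound set by the limit of compound 1: the limit of < 2000 nM in this assay, at which 1 of the 4 values shown sits. The methylcarbamoyl group does not close the large gap to compound 2, with an at least 140-fold lower number from compound 2 to compound 4 (2.15 log units; beyond the scatter), again a bound, this time set by the limit of compound 2: the limit of > 1000000 nM in this assay, at which 1 of the 4 values shown sits.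

A single pair cannot tell whether the step depends on the amide hydrogen, the carbonyl or simply the larger group, and carbamoyl, dimethylcarbamoyl or a carboxylic acid at this place would separate these readings. Also open, going by these compounds, is how a dimethylaminomethyl group or another amine at this same place would compare with methylcarbamoyl, and whether the step carries over to other groups on the shared core.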